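Inverting both stereocentres of compound 2

The source may report more compounds than this note shows. Statements on the series, on what has been measured and on what is new or still open speak of the compounds shown alone.

Measured in a functional assay (blood) for inhibition, with Homo sapiens as the target (a higher number here means a weaker inhibitor, a lower number a stronger inhibitor), for the two compounds so far:
- compound 1 (`CO[C@@]1(c2cc(F)cc(OCc3ccc4c(ccc(=O)n4C)c3)c2)CCO[C@@H](C)C1`) at 1760 nM as its half-maximal inhibitory concentration
- compound 2 (`CO[C@@]1(c2cc(F)cc(OCc3ccc4c(ccc(=O)n4C)c3)c2)CCO[C@H](C)C1`) at 670 nM as its half-maximal inhibitory concentration

Compound 2 holds the lower of these two numbers, so it is the stronger inhibitor of the pair. The next compound, compound 3 (`CO[C@]1(c2cc(F)cc(OCc3ccc4c(ccc(=O)n4C)c3)c2)CCO[C@@H](C)C1`), relates to it as follows: the two compounds have the same atoms and bonds and differ only in configuration as drawn: 2 of 2 stereo elements differ (all stereocentres are inverted: mirror images); a stereocentre at a saturated ring carbon is drawn S in compound 2 and R in compound 3; a stereocentre at a saturated ring carbon is drawn R in compound 2 and S in compound 3 in all. Within the data shown here, only one measured step bears on this change: a 2.6-fold lower number from compound 1 to compound 2 (0.42 log units; beyond the scatter), a modest move that altered a single stereocentre. From the compounds shown here alone, the other stereocentre is the same in compound 1 and compound 2, so its inversion remains untested. A step larger than the measured one is therefore expected in this assay, towards a lower number, though this direction is a judgement and the data do not settle it. The estimated change is a 5.6-fold lower number from compound 2 to compound 3 (0.75 log units; beyond the scatter) in size. For compound 3 the expected value is 120 nM as a middle figure, with an estimated range from 25 nM to 800 nM overall.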

Compound 3, half-maximal inhibitory concentration: 17 nM
The estimate for compound 3 lay 7.1-fold (0.85 log units) above the measured number, and the stated range ends above it.
By their numbers in this assay, from the lowest: compound 3; then compound 2; then compound 1.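

The stereocentre that stayed the same between compound 1 and compound 2 turns out to matter more in this assay: inverting it alone gives a 100-fold lower number from compound 1 to compound 3 (2.02 log units; beyond the scatter) and so far outweighs the other single inversion, which gave a 2.6-fold lower number from compound 1 to compound 2 (0.42 log units; beyond the scatter) in the earlier pair. The mirror-image pair shows a 39-fold lower number from compound 2 to compound 3 (1.60 log units; beyond the scatter) so this read-out separates the two forms sharply. Compound 3 is the strongest inhibitor of the three, with its steps to both others beyond the scatter.

From the compounds shown here alone, what the fourth arrangement of the two stereocentres, the mirror image of compound 1, would give remains open. Going by these compounds, it is also open whether the advantage of compound 3 would hold with an amine or a carboxylic acid in place of the methoxy group, and why this one stereocentre counts for so much.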